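Cytotoxicity on Liver Cells: Trading a Bicyclic Acyl Group for Phenoxy

This account rests on a few compounds, and the source may have more. Where it says the series, first, only, none or still open, it means among the compounds named here.

Compound 1: `O=C(NC(=S)N1CCc2c(OCCCCCOc3ccc(Cl)cc3)cccc21)c1cccs1` gives 10700 nM in an ADME assay on Huh-7 cells (Homo sapiens) for cytotoxicity; a lower number here means that less compound is tolerated, a higher number that more compound is tolerated.
Compound 2: `O=C(NC(=S)N1CCc2c(OCCCCCOc3ccc(Cl)cc3)cccc21)c1cc2ccccc2s1` gives > 50000 nM in this assay, a limit rather than a number.

Compound 2 therefore sits at the upper edge of what this assay reports, as the limit of > 50000 nM in this assay, at which 1 of the 2 values shown sits, records. For the measured compounds named here, the only measured step, an at least 4.6-fold higher number from compound 1 to compound 2 (0.66 log units; beyond the scatter), moved toward greater tolerance. Compound 3 (`S=C(NC(=S)N1CCc2c(OCCCCCOc3ccc(Cl)cc3)cccc21)Oc1ccccc1`) carries a different change: a group of 9 heavy atoms (7 carbon, 1 oxygen, 1 sulfur; one six-membered aromatic ring of carbon only) in place of a group of 11 heavy atoms (9 carbon, 1 oxygen, 1 sulfur; one five-membered aromatic ring with 1 hetero atom, one six-membered aromatic ring of carbon only), on an amide-type nitrogen. Going by the values given here, no measured step covers this change, so the expectation rests on compound 2 alone. Compound 3 is expected to remain near the limit, with an estimated 40000 nM, between 15000 nM and 100000 nM, meaning an expected step of an at least 1.2-fold lower number from compound 2 to compound 3 (0.09 log units; that floor lies within the scatter).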

Compound 3, half-maximal cytotoxic concentration: > 50000 nM
Compound 3 gave a limit, no number; the forecaster's own chance of this, stated with the estimate: 50%; middle value at least 1.2-fold (0.09 log units) away from the limit.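

The (1-benzothiophen-2-yl)carbonyl group is not needed on this amide-type nitrogen to reach the top of the reported range: the group in compound 3, with one six-membered aromatic ring of carbon only, gives an at least 4.6-fold higher number from compound 1 to compound 3 (0.66 log units; beyond the scatter). In this assay compound 3 gives > 50000 nM, a limit and not a number. The step from compound 2 to compound 3 cannot be read, and the limit now holds most of the values: the limit of > 50000 nM in this assay, at which 2 of the 3 values shown sit.

On these data alone, it remains open how an acetyl group or a group carrying an amine would fare on this nitrogen. As far as these compounds go, the true tolerated concentrations of compound 2 and compound 3 also remain unknown.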